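The source may report more compounds than this note shows. Statements on the series, on what has been measured and on what is new or still open speak of the compounds shown alone.

Measured so far, in the same assay:

compound 1, `CCOC(=O)N1CCN(C(=O)c2nc(Nc3cc(C4CC4)[nH]n3)c3cc(Cl)ccc3n2)C[C@H]1C` — 79.2%
compound 2, `C[C@@H]1CN(C(=O)c2nc(Nc3cc(C4CC4)[nH]n3)c3cc(Cl)ccc3n2)CCN1C(=O)OCc1ccccc1` — 74%
compound 3, `C[C@@H]1CN(C(=O)c2nc(Nc3cc(C4CC4)[nH]n3)c3cc(Cl)ccc3n2)CCN1C(=O)OCC(Cl)(Cl)Cl` — 63%

All three share one core and differ only in the group carried on the oxygen of a carbamate. In an assay for inhibition of serine/threonine-protein kinase PAK 4 (Homo sapiens), read by FRET and Z'-LYTE, with a stated time of 60 min, tested at 5 uM, in the presence of a further agent that is not named here (on this read-out lower numbers stand for a weaker effect and higher numbers for a stronger effect at the one concentration tested), compound 3 stands lowest of the three. The steps of a number 16.2 percentage points lower from compound 1 to compound 3 (beyond the scatter) and a number 11 percentage points lower from compound 2 to compound 3 (beyond the scatter) both lie beyond the scatter, whereas a number 5.2 percentage points lower from compound 1 to compound 2 (within the scatter) lies within it, so the methyl and phenyl variants cannot be told apart on these numbers, and only the trichloromethyl variant falls clearly behind.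

Compound 4, `CC(OC(=O)N1CCN(C(=O)c2nc(Nc3cc(C4CC4)[nH]n3)c3cc(Cl)ccc3n2)C[C@H]1C)OC(=O)C(C)(C)C`, has not yet been measured. It changes the same place once more: 1-(((tert-butyl)carbonyl)oxy)ethyl in place of 2,2,2-trichloroethyl on an oxygen next to a carbonyl group. Among the compounds with values here, the three measured steps are the only guide, and they show that swapping the group on this oxygen moves the read-out by modest amounts at most, with the trichloromethyl-bearing compound 3 at the bottom. Since the incoming group is neither of the two that have been tried, the most reasonable expectation is a partial return toward the numbers of compound 1 and compound 2, of modest size and upward. Compound 4 is therefore expected to give 70%, within a range of 56% to 82%. The step this estimate implies is a number 7 percentage points higher from compound 3 to compound 4 (within the scatter).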

Compound 4, a percentage reported as inhibition, at one concentration (the size of the read-out at that concentration, not a potency): 23.6%
Compound 4: middle estimate off by 46.4 percentage points, on the high side; the whole stated range lies above it.
By their numbers in this assay, from the lowest: compound 4; then compound 3; then compounds 2 and 1 (each within the scatter of the next).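

In this assay, within the data shown here, the earlier compounds suggested that this oxygen accepts changes with only modest effect, but the entry of 1-(((tert-butyl)carbonyl)oxy)ethyl breaks that picture: the read-out shows a number 39.4 percentage points lower from compound 3 to compound 4 (beyond the scatter) and a number 50.4 percentage points lower from compound 2 to compound 4 (beyond the scatter). The closest comparison is with compound 1, where ((tert-butyl)carbonyl)oxy simply takes the place of hydrogen on a saturated chain carbon bound to an oxygen next to a carbonyl group and a saturated chain carbon, and even this single replacement gives a number 55.6 percentage points lower from compound 1 to compound 4 (beyond the scatter). The position is therefore far less forgiving than the three earlier groups implied, and all three steps are large, with compound 4 clearly lowest of the four.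

The compounds shown leave open whether the ester part of the entering group accounts for the fall, or whether a smaller acetoxy group or a plain longer chain such as butyl on the same oxygen would lower the number just as far. Nothing available here gives a reason for the fall.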